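A Group Exchange on Compound 1

The source may report more compounds than this note shows. Statements on the series, on what has been measured and on what is new or still open speak of the compounds shown alone.

Compound 1 `O=C(COc1ccc(CNC2CC=C(c3c[nH]c4cccc(F)c34)CC2)c(F)c1)NO`: 189 nM
Compound 2 `O=C(COc1ccc(C(=O)N2CC=C(c3c[nH]c4cccc(F)c34)CC2)cc1)NO`: 1490 nM
Compound 3 `Cc1[nH]c2ccccc2c1C1=CCN(Cc2ccc(OCC(=O)NO)cc2F)CC1`: 1600 nM

In a functional assay on SW480 cells (Homo sapiens) for antiproliferative activity, with a stated time of 72 h (a lower number here means a stronger inhibitor, a higher number a weaker inhibitor), compound 1 holds the lowest of the three numbers, and compound 2 and compound 3 both stand higher by more than the usual scatter. Compound 4 `Cc1[nH]c2ccccc2c1C1=CCC(NCc2ccc(OCC(=O)NO)cc2F)CC1` remains unmeasured. Its difference from compound 1 is 2-methyl-1H-indol-3-yl in place of 4-fluoro-1H-indol-3-yl on a double-bonded ring carbon, with 2-methyl-1H-indol-3-yl in place of 4-fluoro-1H-indol-3-yl on a double-bonded ring carbon. For the measured compounds named here, no measured pair shows this change alone. Compound 3 carries the same 2-methyl-1H-indol-3-yl and gives 1600 nM, so a moderate rise in this assay is expected, though compound 3 also differs from compound 4 elsewhere. The expected change is a 1.9-fold higher number from compound 1 to compound 4 (0.27 log units; within the scatter). For compound 4 the estimated value is 350 nM, with an expected range of 110 nM to 1100 nM.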

Compound 4, half-maximal inhibitory concentration: 170 nM
The estimate for compound 4 lay 2.1-fold (0.31 log units) above the measured number, and the stated range covers the measured number.
By their numbers in this assay, from the lowest: compounds 4 and 1 (each within the scatter of the next); then compounds 2 and 3 (each within the scatter of the next).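

In this assay, 2-methyl-1H-indol-3-yl in place of 4-fluoro-1H-indol-3-yl on a double-bonded ring carbon gives a 1.1-fold lower number from compound 1 to compound 4 (0.05 log units; within the scatter) and stays within the scatter, so this position takes either group with no readable change. For the compounds shown here, this pair is the first to show the exchange alone, and here the 2-methyl-1H-indol-3-yl group carries no rise. Nothing at hand gives a reason for this match. Still open, as far as these compounds go, is how an unsubstituted 1H-indol-3-yl, or one carrying both the 2-methyl and the 4-fluoro groups, would behave at this place.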